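Ortho bromo on the benzyl arm: expectation from fluoro

The source may report more compounds than this note shows. Statements on the series, on what has been measured and on what is new or still open speak of the compounds shown alone.

Compound 1 `c1ccc(CSc2nnc(-c3ccc4c(c3)OCCO4)n2-c2ccccc2)cc1` is a benzylsulfanyl triazole. In a functional assay on HepG2 cells (Homo sapiens) for antiproliferative activity, read by MTT assay, with a stated time of 24 h (a higher number here means a weaker inhibitor, a lower number a stronger inhibitor), compound 1 gives 5960 nM, the highest number among the three measured compounds, meaning it is the weakest inhibitor of the set. Its two neighbours are compound 2 `Fc1ccccc1CSc1nnc(-c2ccc3c(c2)OCCO3)n1-c1ccccc1`, which gives 810 nM, and compound 3 `Fc1cccc(F)c1CSc1nnc(-c2ccc3c(c2)OCCO3)n1-c1ccccc1`, which gives 2070 nM. Both carry fluorine on the benzyl ring, and both move the number down beyond the scatter: a 7.4-fold lower number from compound 1 to compound 2 (0.87 log units; beyond the scatter) and a 2.9-fold lower number from compound 1 to compound 3 (0.46 log units; beyond the scatter). Going from compound 2 to compound 3 by adding a second fluorine gives a 2.6-fold higher number from compound 2 to compound 3 (0.41 log units; beyond the scatter), so one fluorine did more than two.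

The unmeasured compound 4 `Brc1ccccc1CSc1nnc(-c2ccc3c(c2)OCCO3)n1-c1ccccc1` differs from compound 1 as follows: bromo in place of hydrogen on an aromatic carbon. The change sits at the same aromatic carbon where compound 2 carries fluoro, ortho to a large group. Within the data shown here, the step that bears on it most is therefore the one from compound 1 to compound 2, a modest lowering beyond the scatter. Bromo is a different halogen from fluoro, so the size of its effect is uncertain, but a lowering in the same direction is the reasonable expectation. Compound 4 is estimated at 1500 nM, with a range from 500 nM to 4500 nM, which means an expected step of a 4.0-fold lower number from compound 1 to compound 4 (0.60 log units; beyond the scatter).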

Compound 4, half-maximal inhibitory concentration: 4730 nM
Estimate against measurement, compound 4: 3.2-fold (0.50 log units) below; the whole stated range lies below it.
By their numbers in this assay, from the lowest: compound 2; then compound 3; then compounds 4 and 1 (each within the scatter of the next).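

In this assay, the lowering seen with fluoro at this aromatic carbon does not carry over to bromo, and compound 4 cannot be told apart from the unsubstituted benzyl compound (a 1.3-fold lower number from compound 1 to compound 4 (0.10 log units; within the scatter)). Placing a halogen here is therefore not enough on its own: which halogen it is makes a clear difference at this one carbon (a 5.8-fold higher number from compound 2 to compound 4 (0.77 log units; beyond the scatter)), and the 2-bromobenzyl compound also has a higher number than the compound carrying two fluoro groups (a 2.3-fold higher number from compound 3 to compound 4 (0.36 log units; beyond the scatter)). Nothing measured on these compounds gives a reason for this difference between fluoro and bromo.

Chloro at this same aromatic carbon remains an open case, as it could follow either fluoro or bromo, and a methyl or methoxy group there could show whether the lowering extends beyond fluoro to groups that are not halogens. On these data alone, it also remains open whether bromo on another carbon of the same ring would behave as it does here, or whether it would give a lower number like the one seen with fluoro.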